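The compounds below may be only part of what the source reports. "The series", "measured", "known", "first", "only" and "open" are said of these compounds alone.

Measured in a functional assay on HCT-116 cells (Homo sapiens) for antiproliferative activity, read by MTT assay, with a stated time of 72 h; a lower number here means a stronger inhibitor, a higher number a weaker inhibitor:
- compound 1 `O=C1COc2ccc(-c3cnc(Cl)c(NS(=O)(=O)c4ccc(F)cc4)c3)cc2N1C1CCCCC1`: > 40000 nM, a limit
- compound 2 `COc1ncc(-c2ccc3c(c2)N(C2CCCCC2)C(=O)CO3)cc1NS(=O)(=O)c1ccc(F)cc1`: > 40000 nM, a limit
- compound 3 `O=C1COc2ccc(-c3cnc4ccccc4c3)cc2N1C1CCCCC1`: > 40000 nM, a limit

Compound 1 offers no true number as a starting point, only a limit of the assay. The whole set shares this reading: the limit of > 40000 nM in this assay, at which 3 of the 3 values shown sit. None of these compounds can therefore be ranked against another.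

The next compound, compound 4 `Cc1ccc(N2C(=O)COc3ccc(-c4cnc(Cl)c(NS(=O)(=O)c5ccc(F)cc5)c4)cc32)cc1`, keeps the core of compound 1 and changes one group: 4-methylphenyl in place of cyclohexyl on an amide-type nitrogen in a ring. In short, 4-methylphenyl stands in place of cyclohexyl on an amide-type nitrogen in a ring.

Going by the values given here, only one measured step can be consulted, and it is a different change, methoxy in place of chloro on an aromatic carbon: a step that the two limits leave unreadable from compound 1 to compound 2. Going by these compounds, its size is unknown. All three measured compounds also carry the cyclohexyl, so the set shows nothing about replacing that group.

With no measured sign of a gain or a loss, no step beyond the usual scatter is expected in this assay, and a further limit is the likeliest result. The estimated change is a number no higher from compound 1 to compound 4 (the limit leaves the size open). For compound 4 the estimate is 40000 nM, with an expected range from 12000 nM to 100000 nM.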

Compound 4, half-maximal inhibitory concentration: 34300 nM
Compound 4: the middle estimate sits 1.2-fold (0.07 log units) above what was measured; the range from low to high includes it.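

In this assay, going by these compounds alone, compound 4 gives 34300 nM, the first true number in this set and the first reading of any change on the amide-type nitrogen in a ring. With 4-methylphenyl in place of cyclohexyl at that nitrogen, the step is an at least 1.1-fold lower number from compound 1 to compound 4 (0.06 log units; that floor lies within the scatter); only a floor is known, so the real size of this step could be small or large, and the floor alone does not set the two compounds apart. What compound 4 adds is a measured value on this core from which later changes could be read, whereas the other compounds offer none: the limit of > 40000 nM in this assay, at which 3 of the 4 values shown sit.

The compounds shown leave open whether the gain in readability comes from the aromatic ring or from its methyl, and a plain phenyl, a 4-methoxyphenyl or a 4-aminophenyl on the same nitrogen would begin to separate those two parts. Going by these compounds, the step with methoxy in place of chloro cannot be read, so the effect of that change remains unknown, and it could now be tested with the 4-methylphenyl in place.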